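The source may hold more compounds than are shown below. What is called first, only, known or untested is meant among the compounds shown, and "the series" means these compounds.

Working notes on the series. Compound 1 `Cc1cccc(NC(=S)N/N=C/c2ccc3ccccc3n2)c1` in a functional assay on SGC-7901 cells (Homo sapiens) for antiproliferative activity, read by sulforhodamine B assay, with a stated time of 72 h (on this read-out lower numbers stand for stronger inhibition and higher numbers for weaker inhibition), gives > 100000 nM, which is a limit of the assay rather than a number. Compound 1 therefore sits at the limit of > 100000 nM in this assay, at which 1 of the 2 values shown sits. For the measured compounds named here, compound 2 `CN(C)C(=S)N/N=C/c1cnc2ccccc2n1` in this assay gives 170 nM; no step between compound 1 and compound 2 is set out, so the two values stand only side by side and nothing is read from their gap.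

Compound 3 `S=C(N/N=C/c1ccc2ccccc2n1)Nc1cccc(Cl)c1` is still to be measured in this assay. It differs from compound 1 in a single place: chloro in place of methyl on an aromatic carbon. Going by the values given here, with only a limit for compound 1 and no step between measured compounds in hand, the size of this step in this assay cannot be taken from any measured pair. The expectation is a step that stays within the scatter, with at most a modest gain for compound 3, and a fair chance that compound 3 also returns only a limit. Compound 3 is estimated at 80000 nM, within a range of 20000 nM to 200000 nM. The step this estimate means, an at least 1.2-fold lower number from compound 1 to compound 3 (0.09 log units; that floor lies within the scatter), is the one expected.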

Compound 3, half-maximal inhibitory concentration: 61300 nM
The estimate for compound 3 lay 1.3-fold (0.12 log units) above the measured number; the range from low to high includes it.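

Chloro in place of methyl on an aromatic carbon, meta to a large group, gives an at least 1.6-fold lower number from compound 1 to compound 3 (0.21 log units; that floor lies within the scatter) in this assay. Compound 3 gives 61300 nM, so the 3-chlorophenyl compound yields a measured number in this assay, which the series did not yet have for this substitution on the aromatic ring, though a weak one that marks no more than a small shift that cannot be told from the scatter. Compound 1 remains a limit of the assay, so the step is only a floor and its true size stays unread: the limit of > 100000 nM in this assay, at which 1 of the 3 values shown sits.

On these data alone, whether an amine, a methoxy group or a carboxylic acid on the same aromatic carbon would move the number further than chloro does remains open, as does whether the change from methyl to chloro would give a step of similar size on the core of another compound. For the compounds shown here, compound 2 gives 170 nM, but no step links it to either of the other compounds, so its gap to them cannot be read and what separates it from them stays unresolved.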